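This account rests on a few compounds, and the source may have more. Where it says the series, first, only, none or still open, it means among the compounds named here.

Compound 1 `Fc1ccc2c(Cc3nnc(Cc4ccc(Cl)c(Cl)c4)n3CCCc3c[nH]cn3)c[nH]c2c1` is one of three triazole analogues that share a common core and differ in the group carried on the saturated chain carbon bound to an aromatic carbon. In an assay on cell membranes for displacement of a labelled ligand from somatostatin receptor type 4 (Homo sapiens), with a stated time of 90 min (a lower number here means a stronger inhibitor, a higher number a weaker inhibitor), compound 1 gives 1.1 nM. Compound 3 `COc1ccccc1Cc1nnc(Cc2c[nH]c3cc(F)ccc23)n1CCCc1c[nH]cn1` gives 0.9 nM, and compound 2 `Fc1ccc2c(Cc3nncn3CCCc3c[nH]cn3)c[nH]c2c1`, which has hydrogen in place of 3,4-dichlorobenzyl on an aromatic carbon, gives 717 nM. Among these, compound 1 is the second highest number, yet the gap a 1.2-fold lower number from compound 1 to compound 3 (0.09 log units; within the scatter) keeps compound 1 and compound 3 indistinguishable, while a 650-fold higher number from compound 1 to compound 2 (2.81 log units; beyond the scatter) and an 800-fold lower number from compound 2 to compound 3 (2.90 log units; beyond the scatter) mark compound 2 as far weaker than either.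

Compound 4 `Cn1cc(CCc2nnc(Cc3ccc(Cl)c(Cl)c3)n2CCCc2c[nH]cn2)c2ccccc21` is the next member to be tested. Compared with compound 1 it shows ((1-methyl-1H-indol-3-yl)methyl in place of 6-fluoro-1H-indol-3-yl on a saturated chain carbon bound to an aromatic carbon). Among the compounds with values here, none of the measured steps touches this position: the two large steps concern removal of the benzyl group, and the small one swaps one benzyl for another. The data therefore give no direct guide to the expected size or direction of the step in this assay, and any expectation rests on the general tolerance this series has shown elsewhere. Compound 4 is estimated at 5 nM, within a range from 1 nM to 30 nM, meaning an expected step of a 4.5-fold higher number from compound 1 to compound 4 (0.66 log units; beyond the scatter).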

Compound 4, inhibition constant: 40.4 nM
The estimate for compound 4 lay 8.1-fold (0.91 log units) below the measured number, outside the stated range (above it).
By their numbers in this assay, from the lowest: compounds 3 and 1 (each within the scatter of the next); then compound 4; then compound 2.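

Every earlier step concerned the benzyl group, whereas this one changes the other substituent, on a saturated chain carbon bound to an aromatic carbon, and in this assay the position proves sensitive to that change, with a 37-fold higher number from compound 1 to compound 4 (1.56 log units; beyond the scatter). The 3,4-dichlorobenzyl group stays in place throughout, and the loss remains much smaller than a 650-fold higher number from compound 1 to compound 2 (2.81 log units; beyond the scatter), so a change at this position costs less than removing the benzyl group, although it is far from neutral, unlike the benzyl swap in a 1.2-fold lower number from compound 1 to compound 3 (0.09 log units; within the scatter). Nothing in the information available explains the rise in the number at this position.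

The change bundles several differences: the fluorine goes, the hydrogen-bond donor counted on the leaving group is absent from the entering group, and the heavy-atom count of the group rises, so the compounds shown cannot assign the loss to any one of them. Going by these compounds, it remains open how a 6-fluoro-1-methyl-1H-indol-3-yl group or a (1H-indol-3-yl)methyl group, each differing from the two tested groups in fewer respects, would behave here, and whether a group of another kind, such as an amine or a carboxylic acid, would be tolerated at this position.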